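A few compounds are considered here, and "the series" means these few. Any claim that something is new, unique, unknown or untested is made for them only; others in the source may bear on it.

Compound 1 `N#Cc1ccc(Sc2cccc(N)c2C#N)cc1`: > 200000 nM
Compound 2 `COc1ccccc1S(=O)(=O)c1cccc(N)c1C#N`: 146000 nM

Both compounds were tested in a functional assay on MT4 cells (Homo sapiens) for cytotoxicity; a lower number here means a stronger inhibitor, a higher number a weaker inhibitor. The entry for compound 1, > 200000 nM, is a limit of the assay and not a number. Going by the values given here, compound 2, at 146000 nM, therefore holds the only true number so far. The entry for compound 1 is thus (the limit of > 200000 nM in this assay, at which 1 of the 2 values shown sits).

The next compound to be tested is compound 3 `N#Cc1c(N)cccc1S(=O)(=O)c1ccccc1Br`. It carries bromo in place of methoxy on an aromatic carbon, ortho to a large group (bromo in place of methoxy on an aromatic carbon). Among the compounds with values here, no measured pair isolates a single change, so the data offer no direct guide to the size of this one. The expectation is anchored on compound 2 at 146000 nM. A small move toward a lower number in this assay is expected, and a result within the usual scatter would fit as well. The expected size of the change is a 1.3-fold lower number from compound 2 to compound 3 (0.12 log units; within the scatter). For compound 3 the estimated value is 110000 nM, with an expected range of 45000 nM to 200000 nM.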

Compound 3, half-maximal inhibitory concentration: 40000 nM
The estimate for compound 3 lay 2.8-fold (0.44 log units) above the measured number; measured number outside the range, below it.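

In this assay, the exchange of methoxy for bromo on an aromatic carbon, ortho to a large group, gives the series its first readable step: a 3.7-fold lower number from compound 2 to compound 3 (0.56 log units; beyond the scatter). This shows that the position is not indifferent to the group it carries, since a change in this single place on the shared core moves the number beyond the usual scatter, and compound 3 at 40000 nM gives the series a second true number. Nothing shown bears on why the number moved in this direction.

Compound 1 carries a limit and not a number, and it differs from compound 2 in more than one place, so it adds nothing to the reading of this step: the limit of > 200000 nM in this assay, at which 1 of the 3 values shown sits A single step also leaves open whether the lower number is particular to bromo, or how chloro, fluoro, methyl or an amine in the same place would stand against methoxy and bromo.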